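Trifluoromethyl for butyl on the shared core

The source may hold more compounds than are shown below. What is called first, only, known or untested is meant among the compounds shown, and "the series" means these compounds.

Measured so far in a functional assay on HT-29 cells (Homo sapiens) for antiproliferative activity, read by sulforhodamine B assay, with a stated time of 48 h; a higher number here means a weaker inhibitor of growth, a lower number a stronger inhibitor of growth:
compound 1 `CCCCc1ccc(-c2cc(N3CCC(CNS(N)(=O)=O)CC3)ncn2)cc1` gives 15200 nM
compound 2 `CC(C)(C)c1ccc(-c2cc(N3CCC(CNS(N)(=O)=O)CC3)ncn2)cc1` gives 8900 nM
compound 3 `CCCCc1ccc(-c2cc(N3CCC(CCNS(N)(=O)=O)CC3)ncn2)cc1` gives 13300 nM

Compound 3 holds the second highest of the three numbers. Its nearest neighbour is compound 1, and compound 2 lies furthest from it, yet all three values sit within the scatter of one another, so no ranking among them can be read.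

Compound 4 `NS(=O)(=O)NCCC1CCN(c2cc(-c3ccc(C(F)(F)F)cc3)ncn2)CC1` differs from compound 3 by trifluoromethyl in place of butyl on an aromatic carbon. Among the compounds with values here, one measured step touches the same aromatic carbon: a 1.7-fold lower number from compound 1 to compound 2 (0.23 log units; within the scatter), an exchange of one four-carbon group for another that stayed inside the scatter. The other step, a 1.1-fold lower number from compound 1 to compound 3 (0.06 log units; within the scatter), concerns the chain at the far end of the molecule and was likewise flat. Within the data shown here, no measured step introduces a fluorinated group, so the series offers no direct precedent for trifluoromethyl at this position.

On this basis a step in this assay of no more than the scatter is expected, in no particular direction. Compound 4 is therefore expected at 12000 nM, with a range from 5000 nM to 30000 nM. That estimate amounts to a 1.1-fold lower number from compound 3 to compound 4 (0.04 log units; within the scatter).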

Compound 4, concentration for 50% growth inhibition: 22600 nM
Compound 4: the middle estimate sits 1.9-fold (0.27 log units) below what was measured, within the range that was stated.
By their numbers in this assay, from the lowest: compounds 2, 3, 1 and 4 (each within the scatter of the next, the first and the last beyond it).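

In this assay the exchange gives a 1.7-fold higher number from compound 3 to compound 4 (0.23 log units; within the scatter) and so cannot be told apart from no effect of trifluoromethyl in place of butyl on this aromatic carbon, para to a large group. The position has now carried a group with fluorine as well as the two all-carbon groups, and with the rest of the molecule unchanged, this exchange stays inside the scatter, as did the earlier one, a 1.7-fold lower number from compound 1 to compound 2 (0.23 log units; within the scatter), so no change at this position has yet been resolved in this assay. Nothing available gives a reason for this flat response.

From the compounds shown here alone, whether an amine, a carboxylic acid or a longer chain on this aromatic carbon would give a step beyond the scatter remains open. Also open is whether trifluoromethyl would give a similar step on the side chain of compound 1, since the exchange is shown only on the side chain of compound 3.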